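This account rests on a few compounds, and the source may have more. Where it says the series, first, only, none or still open, it means among the compounds named here.

In an ADME assay on MDCK cells (Canis lupus familiaris) for cytotoxicity, read by sulforhodamine B assay, with a stated time of 48 h (a higher number here means a weaker inhibitor, a lower number a stronger inhibitor), compound 2 `Cc1ccc2nc(NCCCCOc3cc(O)c4c(=O)cc(-c5ccccc5)oc4c3)sc2c1` gives 294 ug/mL. Among the compounds with values here, this is the lowest of the two numbers measured so far; its nearest neighbour is compound 1 `O=c1cc(-c2ccccc2)oc2cc(OCCCCNc3nc4ccccc4s3)cc(O)c12`, which in this assay gives 348 ug/mL, and the step of a 1.2-fold lower number from compound 1 to compound 2 (0.07 log units; within the scatter) lies within the scatter. Compound 3 `O=C(O)c1ccc2nc(NCCCCOc3cc(O)c4c(=O)cc(-c5ccccc5)oc4c3)sc2c1` differs from compound 2 by carboxy in place of methyl on an aromatic carbon. Within the data shown here, the only measured step that bears on this position is the one from compound 1 to compound 2, and it stayed within the scatter; no measured pair shows the effect of a carboxy group at this position. Compound 3 is therefore expected to show no step beyond the scatter, which is what a 1.0-fold higher number from compound 2 to compound 3 (0.01 log units; within the scatter) means. For compound 3 the estimate in this assay is 300 ug/mL, with a range from 150 ug/mL to 600 ug/mL.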

Compound 3, half-maximal inhibitory concentration: 324 ug/mL
Beside the measured number, compound 3's estimate is 1.1-fold (0.03 log units) below it; the range from low to high includes it.
By their numbers in this assay, from the lowest: compounds 2, 3 and 1 (each within the scatter of the next).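

In this assay, replacing methyl with carboxy at this place gives a 1.1-fold higher number from compound 2 to compound 3 (0.04 log units; within the scatter), and replacing hydrogen with carboxy gives a 1.1-fold lower number from compound 1 to compound 3 (0.03 log units; within the scatter). The earlier compounds had shown this place carrying only hydrogen and methyl. It now also carries a group of three heavy atoms with a hydrogen-bond donor and acceptor, and all three numbers remain within the scatter of one another. Nothing measured here accounts for this result.

The compounds shown leave open whether an amine or a sulfonamide on this aromatic carbon would give a step beyond the scatter. They also leave open whether a longer chain between the shared core and the 1,3-benzothiazol-2-yl group would change the number, with or without the carboxy group in place.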